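Shortening the chain on the thiocarbonyl side of compound 3

The source may hold more compounds than are shown below. What is called first, only, known or untested is meant among the compounds shown, and "the series" means these compounds.

Three compounds share a core carrying a chain on an aromatic nitrogen. In a functional assay on the whole organism (stomach) for inhibition, with Rattus norvegicus as the target, at a dose of 100 mg/kg by the intraduodenal route (on this read-out lower numbers stand for less inhibition and higher numbers for more inhibition at the one dose given (going by the name of the read-out)), compound 3 `N=C(S)CCCCCn1nc(-c2ccccc2)ccc1=O` gives 91.4%, the highest of the three numbers. Compound 1 `N=C(S)CCn1ncccc1=O` gives 28.8%, and compound 2 `NC(=O)CCn1nc(-c2ccccc2)ccc1=O` gives -2.8%. Among the measured compounds shown here, the one step measured between neighbours that differ in a single place is a number 94.2 percentage points higher from compound 2 to compound 3 (beyond the scatter), where a group of 6 heavy atoms replaced a group of 3 heavy atoms on a saturated chain carbon two bonds along the chain from an aromatic nitrogen.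

Compound 4 `N=C(S)CCn1nc(-c2ccccc2)ccc1=O` reverses part of that move: a group of 3 heavy atoms (1 carbon, 1 nitrogen, 1 sulfur; no ring) in place of a group of 6 heavy atoms (4 carbon, 1 nitrogen, 1 sulfur; no ring), on a saturated chain carbon, two bonds along the chain from an aromatic nitrogen. For the measured compounds named here, the group of 3 heavy atoms that enters is not the one compound 2 carries, so the step from compound 2 to compound 3 bears only partly on it. Compound 1 carries the same short group as compound 4 but lacks the ring substituent, and its value sits far under that of compound 3. A drop is therefore expected, of about a number 56.4 percentage points lower from compound 3 to compound 4 (beyond the scatter) in this assay. Compound 4 is estimated at 35%, with a range from 5% to 75%.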

Compound 4, a percentage reported as inhibition, in the whole organism at one dose (the size of the read-out at that dose, not a potency): 53.7%
For compound 4 the middle estimate is 18.7 percentage points below the measured one, within the range that was stated.
By their numbers in this assay, from the lowest: compound 2; then compound 1; then compound 4; then compound 3.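

In this assay, swapping the group of 3 heavy atoms that holds oxygen for the one that holds sulfur, with no change in chain length, already gives a number 56.5 percentage points higher from compound 2 to compound 4 (beyond the scatter), so the earlier large step combined two changes. The longer group of 6 heavy atoms still counts on its own, since shortening it to the group of 3 heavy atoms gives a number 37.7 percentage points lower from compound 3 to compound 4 (beyond the scatter). Elsewhere on the core, phenyl in place of hydrogen on an aromatic carbon gives a number 24.9 percentage points higher from compound 1 to compound 4 (beyond the scatter), a modest step beside the other two.

No measurement at hand explains why any of these changes moves the number. Still open, going by these compounds, is how a chain of intermediate length, a still longer chain, or an amine or a carboxylic acid in this place would compare.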